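The source may report more compounds than this note shows. Statements on the series, on what has been measured and on what is new or still open speak of the compounds shown alone.

Working notes on the series. Compound 1 `CCCCCc1ccc(C#Cc2cn(C/C=C\CN3C(=O)c4ccccc4C3=O)c(=O)[nH]c2=O)cc1` returns > 100000 nM in an ADME assay on WI-38 cells (Homo sapiens) for cytotoxicity, read by MTT assay, with a stated time of 3 days (a higher number here means a weaker inhibitor, a lower number a stronger inhibitor), a limit and not a number. Compound 2 `CCCCCC#Cc1cn(C/C=C/CN2C(=O)c3ccccc3C2=O)c(=O)[nH]c1=O` gives 40000 nM in this assay, the only number shown for the set. The other entry, that of compound 1, is a limit (the limit of > 100000 nM in this assay, at which 1 of the 2 values shown sits). Compound 3 `CCCCCc1ccc(C#Cc2cn(C/C=C/CN3C(=O)c4ccccc4C3=O)c(=O)[nH]c2=O)cc1` is still to be measured and differs from compound 2 by 4-pentylphenyl in place of pentyl on a triple-bonded carbon. Within the data shown here, no measured step sets a size for this change, so the expectation leans cautiously toward weaker inhibition, with the step from compound 2 to compound 3 estimated as a 2.5-fold higher number from compound 2 to compound 3 (0.40 log units; beyond the scatter). Compound 3 is thus expected near 100000 nM, within 35000 nM to 300000 nM.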

Compound 3, half-maximal inhibitory concentration: 25000 nM
Compound 3: the middle estimate sits 4.0-fold (0.60 log units) above what was measured, outside the stated range (below it).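

Exchanging pentyl for 4-pentylphenyl on a triple-bonded carbon gives a 1.6-fold lower number from compound 2 to compound 3 (0.20 log units; within the scatter) in this assay, so the two groups are not told apart here. The double bond, by contrast, does separate two compounds, with an at least 4.0-fold lower number from compound 1 to compound 3 (0.60 log units; beyond the scatter), and this step rests on configuration alone: the fact that compounds 1 and 3 differ only in the configuration as drawn. The entry for compound 1 is a limit and not a number: the limit of > 100000 nM in this assay, at which 1 of the 3 values shown sits.

As far as these compounds go, whether an amine or a carboxylic acid on the triple-bonded carbon would move the number beyond the scatter stays open. So does the effect of the Z double bond when pentyl is the group on that carbon.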